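The source may hold more compounds than are shown below. What is called first, only, known or untested is meant among the compounds shown, and "the series" means these compounds.

Working notes on the series. The shared core of compound 1 `Cc1nc(-c2ccccc2)sc1C(=O)CSc1nc(-c2ccccc2)c(C#N)c(=O)[nH]1` carries an unsubstituted phenyl; compound 2 `Cc1nc(-c2ccccc2)sc1C(=O)CSc1nc(-c2cccc(Cl)c2)c(C#N)c(=O)[nH]1` bears a chloro on that ring and compound 3 `Cc1nc(-c2ccccc2)sc1C(=O)CSc1nc(-c2ccc(Cl)c(Cl)c2)c(C#N)c(=O)[nH]1` a 3,4-dichlorophenyl. In a functional assay on U-87MG ATCC cells for antiproliferative activity against U-87 MG (Homo sapiens), read by MTT assay, with a stated time of 48 h, tested at 10 uM (a lower number here means a stronger effect, a higher number a weaker effect of the compound at the concentration tested), compound 1 gives 87.5%, compound 2 gives 83.7% and compound 3 gives 92.5%. Compound 2 stands apart from the other two only within the scatter: a number 3.8 percentage points lower from compound 1 to compound 2 (within the scatter), a number 8.8 percentage points higher from compound 2 to compound 3 (within the scatter), and likewise a number 5 percentage points higher from compound 1 to compound 3 (within the scatter).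

Compound 4 `COc1ccc(-c2nc(C)c(C(=O)CSc3nc(-c4cccc(Cl)c4)c(C#N)c(=O)[nH]3)s2)cc1` differs from compound 2 by methoxy in place of hydrogen on an aromatic carbon, on the other aromatic ring of the core. Going by the values given here, no measured step touches that ring; the three known steps all concern chloro substitution on the phenyl at the other end, and each stays within the scatter. There is thus no measured basis for a shift beyond the scatter in this assay for compound 4, and the expectation is none.

The estimate for compound 4 is therefore 85% in this assay, with a range from 70% to 98%. The expected step is a number 1.3 percentage points higher from compound 2 to compound 4 (within the scatter), within the scatter.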

Compound 4, a percentage reported as activity, at one concentration (the size of the read-out at that concentration, not a potency): 90.6%
For compound 4 the middle estimate is 5.6 percentage points below the measured one; the range from low to high includes it.
By their numbers in this assay, from the lowest: compounds 2, 1, 4 and 3 (each within the scatter of the next).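

In this assay, going by these compounds alone, the change from phenyl to 4-methoxyphenyl, on an aromatic ring that no earlier step touched, gives a number 6.9 percentage points higher from compound 2 to compound 4 (within the scatter) and so shows that this ring can carry a methoxy, para to a large group, on the background of compound 2 without a step beyond the scatter. The chloro steps among the earlier compounds stayed within the scatter too, so no change shown so far separates any two compounds in this series. No measurement of any property of these compounds bears on this step.

On these data alone, with one substituent on one background, it stays open whether an amine, a carboxylic acid or a longer alkoxy chain on this ring would move the number beyond the scatter. Also open, as far as these compounds go, is whether methoxy gives a similar step on the unsubstituted phenyl of compound 1 or the 3,4-dichlorophenyl of compound 3.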